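The compounds below may be only part of what the source reports. "The series", "measured", "known", "first", "only" and "open" are said of these compounds alone.

Compound 3 `COc1ccc(-c2nc3cc(C(F)(F)F)ccc3[nH]2)c([N+](=O)[O-])c1` is measured in an ADME assay on Vero cells (Chlorocebus sabaeus) for cytotoxicity (a higher number here means that more compound is tolerated, a lower number that less compound is tolerated), where compound 3 gives 20000 nM. Compound 2 `COc1ccc(-c2nc3cc(C(F)(F)F)ccc3[nH]2)cc1` gives 15000 nM in this assay, and the two sit within the scatter of each other: a 1.3-fold higher number from compound 2 to compound 3 (0.12 log units; within the scatter). Compound 1 `COc1ccc(-c2nc3cc(C(F)(F)F)ccc3[nH]2)c(OC)c1` gives only a limit in this assay, namely > 100000 nM. From there, an at least 6.6-fold lower number from compound 1 to compound 2 (0.82 log units; beyond the scatter) and an at least 5.0-fold lower number from compound 1 to compound 3 (0.69 log units; beyond the scatter). Compound 4 `COc1ccc(-c2nc3cc(C(F)(F)F)ccc3[nH]2)c(N)c1` differs from compound 3 in that (amino in place of nitro on an aromatic carbon). For the measured compounds named here, no measured step exchanges a nitro for an amino; the steps that touch this carbon show that removing the methoxy lowered the number, whereas hydrogen against nitro stayed within the scatter. The step of no change at the digits printed from compound 3 to compound 4 (within the scatter) is therefore expected to stay within the scatter. The estimate for compound 4 is 20000 nM, with a range from 8000 nM to 50000 nM.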

Compound 4, half-maximal cytotoxic concentration: 50000 nM
For compound 4 the middle estimate is 2.5-fold (0.40 log units) below the measured one, and the stated range covers the measured number.
By their numbers in this assay, from the lowest: compounds 2 and 3 (each within the scatter of the next); then compound 4. At a limit, above all of these: compound 1.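

In this assay, this carbon now shows a difference that hydrogen and nitro did not: amino stands apart from both, with a 2.5-fold higher number from compound 3 to compound 4 (0.40 log units; beyond the scatter) and a 3.3-fold higher number from compound 2 to compound 4 (0.52 log units; beyond the scatter). Against methoxy the comparison gives only a floor, an at least 2.0-fold lower number from compound 1 to compound 4 (0.30 log units; that floor lies within the scatter), so amino and methoxy cannot be separated on these data, since compound 1 gives only a limit: the limit of > 100000 nM in this assay, at which 1 of the 4 values shown sits.

Going by these compounds, whether a hydroxyl, an acetamide or a dimethylamino group at this carbon would give a number like that of compound 4 remains open. So does the true distance between compound 1 and compound 4.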